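The source may report more compounds than this note shows. Statements on the series, on what has been measured and on what is new or still open speak of the compounds shown alone.

Of the compounds shown here, three have been measured in an ADME assay on HEK293 cells for agonist activity at metabotropic glutamate receptor 5 (Rattus norvegicus), read by fluorescence and calcium flux; a lower number here means a smaller maximal response, a higher number a larger maximal response. Compound 1 `C[C@@H](NC(=O)c1ccc(C#Cc2ccccc2F)cn1)C(C)(C)O` gives 29.6%, compound 2 `C[C@@H](NC(=O)c1ncc(C#Cc2cccc(F)c2)cn1)C(C)(C)O` gives 19.2%, and compound 3 `C[C@@H](NC(=O)c1ccc(C#Cc2cccc(F)c2)cn1)C(C)(C)C` gives 31.2%, the largest of the three numbers; its gap to compound 1 lies within the scatter, while its gap to compound 2 lies beyond it. Compound 4 `C[C@H](NC(=O)c1ccc(C#Cc2cccc(F)c2)cn1)C(C)(C)C` is compound 3 with one change: the two compounds have the same atoms and bonds and differ only in configuration as drawn: 1 of 1 stereo elements differ; a stereocentre at a saturated chain carbon is drawn R in compound 3 and S in compound 4. For the measured compounds named here, no pair of measured compounds shows what such a change does here, so there is no measured step to lean on. A modest downward step is expected, of a size that may or may not reach beyond the scatter, namely a number 9.2 percentage points lower from compound 3 to compound 4 (within the scatter). Compound 4 is therefore estimated at 22%, between 8% and 38%.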

Compound 4, largest response reached (reported as efficacy), in percent of the reference or control that the assay uses: 20%
The estimate for compound 4 lay 2 percentage points above the measured number; measured number inside the range.
By their numbers in this assay, from the lowest: compounds 2, 4, 1 and 3 (each within the scatter of the next, the first and the last beyond it).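

Inverting the stereocentre at the saturated chain carbon from R to S gives a number 11.2 percentage points lower from compound 3 to compound 4 (beyond the scatter) in this assay. For the compounds shown here, this is the first comparison here between compounds that differ in one place, and it shows that the maximal response depends on the configuration at this carbon. The drop can be assigned to the stereocentre alone because nothing else separates the pair: the fact that compounds 3 and 4 differ only in the configuration as drawn

This single pair cannot show whether inversion has a similar effect on other chains. Going by these compounds, a chain ending in an amine or a cyclopropyl ring, for example, remains open.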